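The source may report more compounds than this note shows. Statements on the series, on what has been measured and on what is new or still open speak of the compounds shown alone.

Within the data shown here, compound 1 `C=CC(=O)Nc1cc(Nc2ncc(Cl)c(N3CCc4sccc4C3)n2)c(OC)cc1N1CCN(C)CC1` is one of three compounds measured in a functional assay on A549 cells (Homo sapiens) for cytotoxicity, read by MTT assay; a higher number here means a weaker inhibitor, a lower number a stronger inhibitor. In this assay compound 1 gives 1560 nM, the second highest of the three numbers. Its nearest neighbour, compound 2 `C=C(Cl)C(=O)Nc1cc(Nc2ncc(Cl)c(N3CCc4sccc4C3)n2)c(OC)cc1N(C)CCN(C)C`, gives 654 nM, while compound 3 `COc1cc(N(C)CCN(C)C)c(NC(=O)C=C(C)C)cc1Nc1ncc(Cl)c(N2CCc3sccc3C2)n1` gives 5100 nM. Among the measured compounds shown here, the single measured step, a 7.8-fold higher number from compound 2 to compound 3 (0.89 log units; beyond the scatter), concerns the group on the carbonyl carbon of the amide and not the substituent on the aromatic ring that is varied here.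

Compound 4 `C=CC(=O)Nc1ccc(OC)c(Nc2ncc(Cl)c(N3CCc4sccc4C3)n2)c1` differs from compound 1 by hydrogen in place of 4-methylpiperazin-1-yl on an aromatic carbon. For the measured compounds named here, no measured step in this set touches the 4-methylpiperazin-1-yl group, so the record gives no direct guide to the size of this change. Removing a group of this size from the shared core is expected to shift the number, and the estimate therefore leans toward a modest rise with a wide range: compound 4 is expected to give 3200 nM, between 800 nM and 13000 nM. This estimate means the step of a 2.1-fold higher number from compound 1 to compound 4 (0.31 log units; beyond the scatter) is expected to be a weakening beyond the scatter, though with considerable uncertainty.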

Compound 4, half-maximal inhibitory concentration: 6910 nM
The estimate for compound 4 lay 2.2-fold (0.33 log units) below the measured number, within the range that was stated.
By their numbers in this assay, from the lowest: compound 2; then compound 1; then compounds 3 and 4 (each within the scatter of the next).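

In this assay, hydrogen in place of 4-methylpiperazin-1-yl on the aromatic carbon gives a 4.4-fold higher number from compound 1 to compound 4 (0.65 log units; beyond the scatter), which shows that this position, not touched by the earlier step on the carbonyl carbon, affects the number. The change does not abolish the effect, since compound 4 without the group still gives 6910 nM. Nothing measured here speaks to the cause of this rise.

At this position the compounds shown compare only the 4-methylpiperazin-1-yl group with hydrogen, so it remains open whether a smaller amine such as dimethylamino, or a morpholin-4-yl ring, would hold the lower number. Going by these compounds, it is also open whether the step would have the same size with a 1-chloroethenyl or 2-methylprop-1-en-1-yl group on the carbonyl carbon.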